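Carbonyl for sulfonyl on the amine nitrogen of compound 3

This account rests on a few compounds, and the source may have more. Where it says the series, first, only, none or still open, it means among the compounds named here.

Measured so far in a functional assay on PANC-1 cells (Homo sapiens) for inhibition, read by MTT assay, with a stated time of 24 h, tested at 10 uM; a lower number here means less inhibition, a higher number more inhibition at the concentration tested (going by the name of the read-out):
compound 1 `CC(C)=CCC1Cc2c(OCCCNS(=O)(=O)c3ccc([N+](=O)[O-])cc3)cc(=O)n(CCCO)c2CC1(C)C` gives 17.3%
compound 2 `CC(C)=CCC/C(C)=C/CC1Cc2c(OCCCNS(=O)(=O)c3ccc(C(F)(F)F)cc3)cc(=O)n(CCCO)c2CC1(C)C` gives 0%
compound 3 `CC(C)=CCC/C(C)=C/CC1Cc2c(OCCCNS(=O)(=O)c3ccc([N+](=O)[O-])cc3)cc(=O)n(CCCO)c2CC1(C)C` gives 0%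

Compound 3 stands level with compound 2, the two together the lowest of the three numbers; compound 1 sits higher, the step of a number 17.3 percentage points lower from compound 1 to compound 3 (beyond the scatter) lying beyond the scatter. The step of no change at the digits printed from compound 2 to compound 3 (within the scatter) lies within the scatter.

Compound 4 `CC(C)=CCC/C(C)=C/CC1Cc2c(OCCCNC(=O)c3ccc([N+](=O)[O-])cc3)cc(=O)n(CCCO)c2CC1(C)C` differs from compound 3 as follows: (4-nitrophenyl)carbonyl in place of (4-nitrophenyl)sulfonyl on an amine nitrogen. Among the measured compounds shown here, no measured step exchanges a sulfonyl for a carbonyl on the amine nitrogen, so neither recorded step bears directly on it; the one change to the aromatic substituent, no change at the digits printed from compound 2 to compound 3 (within the scatter), was flat. Compound 3 cannot fall further. For compound 4 the expected step is a number 5 percentage points higher from compound 3 to compound 4 (within the scatter), small and likely within the scatter. Compound 4 is accordingly estimated at 5%, between 0% and 20%.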

Compound 4, a percentage reported as inhibition, at one concentration (the size of the read-out at that concentration, not a potency): 6.5%
For compound 4 the middle estimate is 1.5 percentage points below the measured one; the range from low to high includes it.
By their numbers in this assay, from the lowest: compounds 2, 3 and 4 (each within the scatter of the next); then compound 1.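

Working notes: exchanging (4-nitrophenyl)sulfonyl for (4-nitrophenyl)carbonyl on the amine nitrogen gives a number 6.5 percentage points higher from compound 3 to compound 4 (within the scatter) and is the first direct reading at this position. With compound 3 at 0% as the starting point, the step shows only that inhibition stays low with either group on this chain-bearing compound. No supporting data on hand account for the step.

From the compounds shown here alone, whether the same exchange counts for more on compound 1, which carries the 3-methylbut-2-en-1-yl group, stays open. A urea or an acetyl group on this amine nitrogen also remains untested among the compounds shown.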